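Chain-terminus variation on the piperidinyl benzamide series

The source may hold more compounds than are shown below. What is called first, only, known or untested is meant among the compounds shown, and "the series" means these compounds.

Values to date, all in an assay on HEK293 cells for displacement of a labelled ligand from 5-hydroxytryptamine receptor 4 (Homo sapiens), read by scintillation counting; a higher number here means a weaker inhibitor, a lower number a stronger inhibitor:
- compound 1 `COc1cc(N)c(Cl)cc1C(=O)NC1CCNCC1`: 1580 nM
- compound 2 `COc1cc(N)c(Cl)cc1C(=O)NC1CCN(CCCCCCCCO)CC1`: 79.4 nM
- compound 3 `COc1cc(N)c(Cl)cc1C(=O)NC1CCN(CCCCCCCCN2C(=O)c3ccccc3C2=O)CC1`: 39.8 nM

Compound 2 sits second highest of the three numbers. Its nearest neighbour is compound 3, reached by a 2.0-fold lower number from compound 2 to compound 3 (0.30 log units; within the scatter), a change within the scatter. For the measured compounds named here, its furthest is compound 1, with a 20-fold lower number from compound 1 to compound 2 (1.30 log units; beyond the scatter), the one large step so far, brought by 8-hydroxyoctyl in place of hydrogen on the ring amine nitrogen.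

Compound 4 `COc1cc(N)c(Cl)cc1C(=O)NC1CCN(CCCCCN2CCCCC2)CC1` differs from compound 2 by piperidin-1-yl in place of 3-hydroxypropyl on a saturated chain carbon, five bonds along the chain from an amine nitrogen in a ring. Going by the values given here, the only measured step that bears on it is the one from compound 2 to compound 3, where the terminal oxygen of the chain was exchanged for a larger group and the number moved by a 2.0-fold lower number from compound 2 to compound 3 (0.30 log units; within the scatter), within the scatter. Among the compounds with values here, that step argues that the far end of the chain can be reworked without a large shift in this assay; nothing among the measured compounds, however, tests a shorter chain or a ring nitrogen at its end, so the expectation rests on one step only.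

For compound 4 a number near compound 2 is expected, shading lower, i.e. an expected step of a 1.6-fold lower number from compound 2 to compound 4 (0.20 log units; within the scatter). The estimate for compound 4 is 50 nM, with a range from 15 nM to 160 nM.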

Compound 4, inhibition constant: 10 nM
The estimate for compound 4 lay 5.0-fold (0.70 log units) above the measured number; measured number outside the range, below it.
By their numbers in this assay, from the lowest: compound 4; then compounds 3 and 2 (each within the scatter of the next); then compound 1.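

In this assay, the far end of the chain proves not to be silent: there is a 7.9-fold lower number from compound 2 to compound 4 (0.90 log units; beyond the scatter) and this step lies beyond the scatter, while a 2.0-fold lower number from compound 2 to compound 3 (0.30 log units; within the scatter) stayed within it. The change at this position has two parts, since piperidin-1-yl replaces 3-hydroxypropyl on a saturated chain carbon five bonds along from the ring amine nitrogen, so the chain end now carries a ring with a nitrogen and the linking chain is also shorter than the octyl chain of compound 2. No measurement on hand accounts for the shift.

The contribution of the terminal ring and that of the chain length remain unseparated, and a 5-hydroxypentyl chain or an octyl chain ending in piperidin-1-yl would pull them apart. Also open, as far as these compounds go, is how much depends on the terminal ring itself, as against a morpholine, a pyrrolidine or an open dimethylamino group at the same chain end.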